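The source may hold more compounds than are shown below. What is called first, only, known or untested is meant among the compounds shown, and "the series" means these compounds.

Measured so far in a functional assay on CEM/s cells (Homo sapiens) for cytotoxicity; a lower number here means a stronger inhibitor, a higher number a weaker inhibitor:
- compound 1 `C=CC[n+]1cn(C)c2nc[nH]/c(=N\OC)c21`: the assay gives only a limit, > 80000 nM.
- compound 2 `CC(C)=CCC/C(C)=C/CC/C(C)=C/CC/C(C)=C/C[n+]1cn(C)c2nc[nH]/c(=N\OC(C)(C)C)c21`: 3860 nM.
- compound 3 `CO/N=c1\[nH]cnc2c1[n+](C/C=C(\C)CCCC(C)CCCC(C)CCCC(C)C)cn2C`: 7920 nM.

Compound 1 sits at the limit of this assay (the limit of > 80000 nM in this assay, at which 1 of the 3 values shown sits), so it gives no number to compare. Of the two numbers that remain, compound 3 holds the higher one and compound 2 the lower, and the gap between them is beyond the usual scatter. The two differ in more than one place, so the gap is noted here without being assigned to either change.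

Compound 4 `C/C(=C\C[n+]1cn(C)c2nc[nH]/c(=N\OCc3ccccc3)c21)CCCC(C)CCCC(C)CCCC(C)C` is the next member: phenyl in place of hydrogen on a saturated chain carbon bound to an oxygen, which reads at the group level as methoxy going to benzyloxy on the oxime ether of compound 3. Among the compounds with values here, no measured pair shows this change on its own. Compound 2 carries a bulkier alkoxy group than compound 3 and reads lower, so the expectation for compound 4 is a modest fall in this assay, a 1.6-fold lower number from compound 3 to compound 4 (0.20 log units; within the scatter), though a result within the scatter would not surprise. Compound 4 is thus estimated at 5000 nM, within 2000 nM to 15000 nM.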

Compound 4, half-maximal inhibitory concentration: 6300 nM
Estimate against measurement, compound 4: 1.3-fold (0.10 log units) below; the range from low to high includes it.
By their numbers in this assay, from the lowest: compounds 2, 4 and 3 (each within the scatter of the next, the first and the last beyond it). At a limit, above all of these: compound 1.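

Methoxy going to benzyloxy on the oxime ether is the first change in the series that can be read on its own, with the rest of the structure held constant. In this assay the step reads a 1.3-fold lower number from compound 3 to compound 4 (0.10 log units; within the scatter), so at this one pair, phenyl in place of hydrogen on a saturated chain carbon bound to an oxygen, which brings an aromatic ring of 6 heavy atoms, leaves the read-out within the scatter, and the alkoxy position can carry this much larger group without a separable shift in the number. Within the data shown here, nothing measured here gives a reason for that outcome, and the only evidence at hand concerns the assay limit, which does not bear on this step.

From the compounds shown here alone, what an oxime ether group of another kind would give stays open, for instance a benzyloxy whose phenyl ring carries an amine or a carboxylic acid, or a longer chain in place of benzyl. Going by these compounds, whether the same change gives the same reading on the chain of compound 2 also stays open, since this single pair speaks only for the chain of compound 3.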